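A few compounds are considered here, and "the series" means these few. Any claim that something is new, unique, unknown or untested is made for them only; others in the source may bear on it.

Measured so far:
compound 1 `O=C(CN(c1nc(Cl)nc2[nH]cnc12)C1CC1)N[C@@H](CO)C(=O)OCc1ccccc1`, 31.9% in a functional assay on the whole organism (Tail, strain ICR) with Mus musculus as the target, in the tail flick test, with a stated time of 30 min, at a dose of 25 umol/kg by the oral route; a lower number here means a weaker effect, a higher number a stronger effect of the compound at the dose given;
compound 2 `CC[C@H](C)[C@H](NC(=O)CN(c1nc(Cl)nc2[nH]cnc12)C1CC1)C(=O)O`, 30.3% in this assay;
compound 3 `O=C(CN(c1nc(Cl)nc2[nH]cnc12)C1CC1)N[C@@H](CO)C(=O)O`, 38.7% in this assay.

Compound 3 carries the highest of the three numbers, but neither gap to it reaches beyond the scatter: a number 6.8 percentage points higher from compound 1 to compound 3 (within the scatter), and a number 8.4 percentage points higher from compound 2 to compound 3 (within the scatter). On these numbers the three compounds cannot be ordered.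

Compound 4 `O=C(O)CC[C@H](NC(=O)CN(c1nc(Cl)nc2[nH]cnc12)C1CC1)C(=O)O` is not yet measured in this assay. It differs from compound 3 by carboxymethyl in place of hydroxy on a saturated chain carbon, two bonds along the chain from an amide-type nitrogen and a carbonyl carbon. Among the measured compounds shown here, the step that bears on this change is the one in which the group on that chain carbon was exchanged, a number 8.4 percentage points higher from compound 2 to compound 3 (within the scatter), since the change to compound 4 is again an exchange at the same place; that step stayed within the scatter. The ester step, a number 6.8 percentage points higher from compound 1 to compound 3 (within the scatter), touched another part of the molecule and also stayed within the scatter. With only these two small steps as guidance, no movement beyond the scatter is expected in this assay in either direction.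

For compound 4 a value of 34% is therefore estimated, with a range from 20% to 48%. The expected step is a number 4.7 percentage points lower from compound 3 to compound 4 (within the scatter), which is taken to lie inside the scatter.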

Compound 4, a percentage reported as activity, at one dose (the size of the read-out at that dose, not a potency): 26.8%
For compound 4 the middle estimate is 7.2 percentage points above the measured one; measured number inside the range.
By their numbers in this assay, from the lowest: compounds 4, 2, 1 and 3 (each within the scatter of the next, the first and the last beyond it).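

In this assay, among the compounds shown here, the exchange of hydroxymethyl for 2-carboxyethyl on the saturated chain carbon bound to an amide-type nitrogen and a carbonyl carbon gives the first step to pass the scatter, a modest one: a number 11.9 percentage points lower from compound 3 to compound 4 (beyond the scatter). The position is therefore not indifferent to its substituent, yet the effect is limited to this one pair, since the other exchange at the same carbon, a number 3.5 percentage points lower from compound 2 to compound 4 (within the scatter), stays within the scatter and leaves 2-carboxyethyl and sec-butyl indistinguishable. No measured property of these groups is available to account for the step.

As far as these compounds go, it remains open whether the lower number goes with the carboxylic acid at the end of the 2-carboxyethyl group or with the longer chain itself, a question that a 2-carbamoylethyl group, a plain propyl chain or a shorter carboxymethyl group on the same carbon would help to separate. Also open, from the compounds shown here alone, is whether a benzyl ester on the carboxylic acid next to the amide-bearing carbon would change the picture for the 2-carboxyethyl series, and whether the step holds at other doses and times.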